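The source may hold more compounds than are shown below. What is called first, only, known or untested is meant among the compounds shown, and "the series" means these compounds.

Three compounds have been measured in a functional assay on SK-HEP1 cells (Homo sapiens) for antiproliferative activity, read by sulforhodamine B assay, with a stated time of 72 h; a lower number here means a stronger inhibitor, a higher number a weaker inhibitor:

Compound 1 `CCOC(=O)c1cnc2ccc(-c3cnc(OC)c(NS(=O)(=O)c4ccc(F)cc4F)c3)cn12`: 300 nM
Compound 2 `COc1ncc(-c2ccc3ncc(C(=O)O)n3c2)cc1NS(=O)(=O)c1ccc(F)cc1F`: 750 nM
Compound 3 `COc1ncc(-c2ccc3ncc(C(=O)N4CCC(O)CC4)n3c2)cc1NS(=O)(=O)c1ccc(F)cc1F`: 790 nM

Compound 3 stands at the upper end of these numbers, beside compound 2 (a 1.1-fold higher number from compound 2 to compound 3 (0.02 log units; within the scatter)) and clearly apart from compound 1 (a 2.6-fold higher number from compound 1 to compound 3 (0.42 log units; beyond the scatter)). Compound 4 `COc1ncc(-c2ccc3ncc(C(=O)NCc4ccncc4)n3c2)cc1NS(=O)(=O)c1ccc(F)cc1F` differs from compound 3 by ((pyridin-4-yl)methyl)amino in place of 4-hydroxypiperidin-1-yl on a carbonyl carbon. Within the data shown here, the only steps that touch this position are a 2.6-fold higher number from compound 1 to compound 3 (0.42 log units; beyond the scatter) and a 1.1-fold higher number from compound 2 to compound 3 (0.02 log units; within the scatter); no exchange of one amide group for another has been measured. Since the swap from acid to amide left the number unchanged, compound 4 is expected to stay close to compound 3, a step of a 1.1-fold lower number from compound 3 to compound 4 (0.05 log units; within the scatter) in this assay . The estimate for compound 4 is 700 nM, with a range from 300 nM to 1800 nM.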

Compound 4, half-maximal inhibitory concentration: 980 nM
Compound 4: middle estimate off by 1.4-fold (0.15 log units), on the low side, and the stated range covers the measured number.
By their numbers in this assay, from the lowest: compound 1; then compounds 2, 3 and 4 (each within the scatter of the next).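

In this assay the exchange of one amide group for another, ((pyridin-4-yl)methyl)amino in place of 4-hydroxypiperidin-1-yl on a carbonyl carbon, gives a 1.2-fold higher number from compound 3 to compound 4 (0.09 log units; within the scatter), and the acid comparison gives a 1.3-fold higher number from compound 2 to compound 4 (0.12 log units; within the scatter). Only the ethoxy group of compound 1 stands apart, with a 3.3-fold higher number from compound 1 to compound 4 (0.51 log units; beyond the scatter), so the aromatic ring in the new amide separates it from neither the other amide nor the acid. Nothing available explains why these groups read alike. Going by these compounds, whether a simple amine such as dimethylamino on the carbonyl carbon would read with these amides stays open. So does whether methoxy or a longer alkoxy chain there would match compound 1.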